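Aryl variation on the triazole nitrogen: bromophenyl entry

The source may hold more compounds than are shown below. What is called first, only, known or untested is meant among the compounds shown, and "the series" means these compounds.

Three members of the series share one core and differ only in the aryl group on an aromatic nitrogen. Compound 1 `COc1cc2c(Oc3ccc(NC(=O)c4nnn(-c5ccc(C)cc5)c4C(F)(F)F)cc3F)ccnc2cc1OCCCN1CCC(C)CC1` gives 400 nM in a functional assay on A549 cells (Homo sapiens) for cytotoxicity, read by MTT assay, with a stated time of 72 h; on this read-out higher numbers stand for weaker inhibition and lower numbers for stronger inhibition. Compound 2 `COc1cc2c(Oc3ccc(NC(=O)c4nnn(-c5ccccc5C(F)(F)F)c4C(F)(F)F)cc3F)ccnc2cc1OCCCN1CCC(C)CC1` gives 220 nM in this assay. Compound 3 `COc1cc2c(Oc3ccc(NC(=O)c4nnn(-c5ccc(F)c(F)c5)c4C(F)(F)F)cc3F)ccnc2cc1OCCCN1CCC(C)CC1` gives 140 nM in this assay. Compound 3 holds the lowest of the three numbers; the nearest is compound 2, and a 1.6-fold lower number from compound 2 to compound 3 (0.20 log units; within the scatter), while the furthest is compound 1, and a 2.9-fold lower number from compound 1 to compound 3 (0.46 log units; beyond the scatter). The remaining pair shows a 1.8-fold lower number from compound 1 to compound 2 (0.26 log units; within the scatter).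

Compound 4 `COc1cc2c(Oc3ccc(NC(=O)c4nnn(-c5cccc(Br)c5)c4C(F)(F)F)cc3F)ccnc2cc1OCCCN1CCC(C)CC1` is not yet measured. The change from compound 3 is 3-bromophenyl in place of 3,4-difluorophenyl on an aromatic nitrogen.

All three measured steps concern the same position, the aryl group on the aromatic nitrogen, and all are small: one modest step beyond the scatter and two within it. Within the data shown here, no measured step involves a bromine-bearing aryl, so the direction of the step from compound 3 to compound 4 cannot be read from the data. On the size of the three steps at this position, a small step in this assay is expected, most likely within the scatter, with no preferred direction; the expected step is a 1.2-fold higher number from compound 3 to compound 4 (0.08 log units; within the scatter).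

Compound 4 is therefore estimated at 170 nM in this assay, with a range from 60 nM to 480 nM.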

Compound 4, half-maximal inhibitory concentration: 350 nM
Beside the measured number, compound 4's estimate is 2.1-fold (0.31 log units) below it; the range from low to high includes it.
By their numbers in this assay, from the lowest: compounds 3, 2, 4 and 1 (each within the scatter of the next, the first and the last beyond it).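

In this assay, the change to 3-bromophenyl gives a 2.5-fold higher number from compound 3 to compound 4 (0.40 log units; beyond the scatter), so replacing 3,4-difluorophenyl at this aromatic nitrogen gives a modest step beyond the scatter. The other two new steps, a 1.6-fold higher number from compound 2 to compound 4 (0.20 log units; within the scatter) and a 1.1-fold lower number from compound 1 to compound 4 (0.06 log units; within the scatter), lie within the scatter, so 3-bromophenyl cannot be ordered against 2-(trifluoromethyl)phenyl or 4-methylphenyl, and 3,4-difluorophenyl now stands apart from two of the three other aryl groups but not from 2-(trifluoromethyl)phenyl. Nothing available on these compounds accounts for the step from 3,4-difluorophenyl to 3-bromophenyl.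

The compounds shown leave open whether the separation comes from the fluorines of 3,4-difluorophenyl or from the bromine of 3-bromophenyl, as no aryl group here with a single fluorine or with a bromine in another place allows the two to be told apart. They also leave open how the assay responds to an aryl group carrying an amine or a carboxylic acid, since every aryl group shown bears only halogen, methyl or trifluoromethyl.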